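From compound 2 to compound 4: notes on the series

The source may hold more compounds than are shown below. What is called first, only, known or untested is meant among the compounds shown, and "the series" means these compounds.

Compound 2 (`COc1ccc(C2=C(c3cc(OC)c(OC)c(OC)c3)C(=O)C(O)C2)cc1`) is the reference point. In an ADME assay on HT-29 cells (Homo sapiens) for cytotoxicity, read by MTT assay, with a stated time of 72 h (a lower number here means a stronger inhibitor, a higher number a weaker inhibitor), compound 2 gives < 1 ug/mL as a limit of the assay and not a number. Compound 1 (`COc1ccc(C2=C(c3cc(OC)c(OC)c(OC)c3)C(=O)C(OC(C)=O)C2)cc1`) gives < 1 ug/mL as a limit too. Compound 3 (`COc1ccc(C2=C(c3cc(OC)c(OC)c(OC)c3)C(=O)C(O)C2)cc1Cl`) also gives < 1 ug/mL as a limit. The series therefore offers only the limit of < 1 ug/mL in this assay, at which 3 of the 3 values shown sit, and no exact value.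

Compound 4 (`COc1ccc(C2=C(c3cc(OC)c(OC)c(OC)c3)C(=O)C(O[SiH2]C(C)(C)C)C2)cc1`) carries this change: a group of 5 heavy atoms (4 carbon, 1 silicon; no ring) in place of a hydrogen atom, on an oxygen on a saturated carbon.

Going by the values given here, two measured steps bear on it. With acetyl leaving an oxygen on a saturated carbon, the record is a step that the two limits leave unreadable from compound 1 to compound 2 and this is the closer precedent. The chloro change on an aromatic carbon is a step that the two limits leave unreadable from compound 2 to compound 3 and is less direct. Neither gives a size or a direction, so no step beyond the scatter can be forecast in this assay with any confidence. The expected outcome, held loosely, is a step that the limit leaves unreadable from compound 2 to compound 4 and a further limit is quite possible. For compound 4 the estimated value is 0.6 ug/mL with an expected range from 0.1 ug/mL to 3 ug/mL.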

Compound 4, half-maximal inhibitory concentration: 5 ug/mL
For compound 4 the middle estimate is 8.3-fold (0.92 log units) below the measured one; the whole stated range lies below it.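

Oxygen on a saturated carbon is the one place in the series where a change gives a readable result in this assay: the group of 5 heavy atoms (4 carbon, 1 silicon; no ring) in place of a hydrogen atom gives an at least 5.0-fold higher number from compound 2 to compound 4 (0.69 log units; beyond the scatter). Set against acetyl at the same oxygen, the same group gives an at least 5.0-fold higher number from compound 1 to compound 4 (0.69 log units; beyond the scatter), so this position does not treat all groups alike. The earlier steps cannot be read, and the two readable steps give only a minimum size: the limit of < 1 ug/mL in this assay, at which 3 of the 4 values shown sit.

On these data alone, whether an all-carbon chain of similar size, a methyl ether or an amine at this oxygen would shift the number in the same way remains open. Also open, as far as these compounds go, is how far compound 1 and compound 2 actually lie from compound 4, and whether the chloro group of compound 3 alters the outcome of this change.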